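The source may hold more compounds than are shown below. What is called first, only, known or untested is meant among the compounds shown, and "the series" means these compounds.

Measured in a functional assay on MGC-803 cells (Homo sapiens) for inhibition, read by sulforhodamine B assay; on this read-out lower numbers stand for stronger inhibition and higher numbers for weaker inhibition:
- Compound 1 `O=C1C=C(NC2CCCCC2)C(=O)c2c1nc1n2[C@H]2OC[C@@H](O)[C@H]2OC1`: > 8000 nM, a limit of the assay
- Compound 2 `O=C1C=C(Nc2cccc(F)c2)C(=O)c2c1nc1n2[C@H]2OC[C@@H](O)[C@H]2OC1`: 2180 nM
- Compound 3 `COc1ccccc1NC1=CC(=O)c2nc3n(c2C1=O)[C@H]1OC[C@@H](O)[C@H]1OC3`: 1630 nM

Still to be measured is compound 4 `O=C1C=C(Nc2ccc(C(F)(F)F)cc2)C(=O)c2c1nc1n2[C@H]2OC[C@@H](O)[C@H]2OC1`.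

In this assay, compound 3 gives 1630 nM and compound 2 gives 2180 nM, two values within the scatter of each other. Compound 1 gives only a limit, > 8000 nM.

Compound 4 carries 4-(trifluoromethyl)phenyl in place of 2-methoxyphenyl on an amine nitrogen. Among the measured compounds shown here, the closest precedent is the exchange of 3-fluorophenyl for 2-methoxyphenyl at this same place, a 1.3-fold lower number from compound 2 to compound 3 (0.13 log units; within the scatter), which stays within the scatter. The two steps away from cyclohexyl are larger, an at least 3.6-fold lower number from compound 1 to compound 2 (0.56 log units; beyond the scatter) and an at least 4.9-fold lower number from compound 1 to compound 3 (0.69 log units; beyond the scatter), but they do not apply directly, since compound 4 keeps an aromatic ring on the amine nitrogen, as compound 2 and compound 3 do. For the measured compounds named here, no step beyond the scatter is therefore expected in either direction, although this rests on only two measured aromatic groups. The expected step is a 1.2-fold higher number from compound 3 to compound 4 (0.07 log units; within the scatter). Compound 4 is estimated at 1900 nM, with an expected range of 700 nM to 5000 nM.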

Compound 4, half-maximal inhibitory concentration: 2820 nM
Compound 4: middle estimate off by 1.5-fold (0.17 log units), on the low side, within the range that was stated.
By their numbers in this assay, from the lowest: compounds 3, 2 and 4 (each within the scatter of the next). At a limit, above all of these: compound 1.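

With a third aromatic group on the amine nitrogen, this assay still does not separate these groups: a 1.7-fold higher number from compound 3 to compound 4 (0.24 log units; within the scatter) and a 1.3-fold higher number from compound 2 to compound 4 (0.11 log units; within the scatter) both stay within the scatter, although 4-(trifluoromethyl)phenyl brings fluorine atoms and no hydrogen-bond acceptor where 2-methoxyphenyl carries one. The advantage of an aromatic group over cyclohexyl, seen earlier with 3-fluorophenyl and 2-methoxyphenyl, also holds for this third group, with an at least 2.8-fold lower number from compound 1 to compound 4 (0.45 log units; beyond the scatter), and none of the three aromatic groups shown goes against it. Compound 1 gives only a limit of the assay, so this step is a bound and not a measured size: the limit of > 8000 nM in this assay, at which 1 of the 4 values shown sits.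

Cyclohexyl is the only group without an aromatic ring here, so the compounds shown cannot tell whether the aromatic ring itself matters or whether other groups on this nitrogen would do equally well. Also open, from the compounds shown here alone, is whether an unsubstituted phenyl, a benzyl group, a pyridine ring or a short chain ending in an amine would move the number beyond the scatter from the three aromatic compounds.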